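Phenoxymethyl for Phenyl on an Amide Chain

A few compounds are considered here, and "the series" means these few. Any claim that something is new, unique, unknown or untested is made for them only; others in the source may bear on it.

Compound 1 `CCCCCCCCCCC(C)(C)C(=O)Nc1c(C)c([N+](=O)[O-])c(C)c2c1OC(C)(C)C2` gives 36 nM in an assay for inhibition of acyl-CoA:cholesterol acyltransferase (Oryctolagus cuniculus), using microsomes; on this read-out higher numbers stand for weaker inhibition and lower numbers for stronger inhibition; compound 2 `CCCCCCCCCCC1(C(=O)Nc2cccc3c2OC(C)(C)C3)CCCC1` gives 500 nM; compound 3 `Cc1cc(C)c(NC(=O)C(C)(C)CCCCc2ccccc2)c2c1CC(C)(C)O2` gives 210 nM.

Among these three numbers compound 3 stands second highest: its nearest neighbour is compound 2, whose value lies beyond the scatter above it, and furthest from it is compound 1, whose value lies well below it. No two of the three are close enough to count as the same.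

Compound 4 `Cc1cc(C)c(NC(=O)C(C)(C)CCCCCOc2ccccc2)c2c1CC(C)(C)O2` has not yet been measured. Relative to compound 3 it carries phenoxymethyl in place of phenyl on a saturated chain carbon, five bonds along the chain from a carbonyl carbon. Among the compounds with values here, nothing among the measured compounds isolates this change, so what follows is an expectation only. The compound with the lowest number, compound 1, carries the longest saturated chain, and compound 4 extends its chain further than compound 3 does; on that slender basis compound 4 is expected to move toward a somewhat lower number, a step of a 1.4-fold lower number from compound 3 to compound 4 (0.15 log units; within the scatter) that may well stay within the scatter. The estimate for compound 4 is 150 nM, with a range from 50 nM to 450 nM.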

Compound 4, half-maximal inhibitory concentration: 86 nM
Compound 4: the middle estimate sits 1.7-fold (0.24 log units) above what was measured; the measured number falls inside the stated range.
By their numbers in this assay, from the lowest: compound 1; then compound 4; then compound 3; then compound 2.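

Within the data shown here, exchanging phenyl for phenoxymethyl on a saturated chain carbon, five bonds along the chain from a carbonyl carbon, brings a 2.4-fold lower number from compound 3 to compound 4 (0.39 log units; beyond the scatter) in this assay and provides the first comparison here of compounds that differ in one place. The chain end at this position therefore accepts the larger phenoxymethyl group, with its one hydrogen-bond acceptor, and inhibition becomes stronger rather than weaker. Nothing available explains why this single change has this effect.

The compounds shown do not separate the contribution of the ether oxygen from that of the longer chain, which a purely carbon chain of matching length ending in phenyl would address. Also open, going by these compounds, is how an amine in place of the ether oxygen, or a still longer chain before the phenoxy group, would read out.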